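This account rests on a few compounds, and the source may have more. Where it says the series, first, only, none or still open, it means among the compounds named here.

Measured compounds in an assay on isolated protein for inhibition of leukotriene B4 receptor 1 (Homo sapiens), tested at 10 uM; on this read-out lower numbers stand for less inhibition and higher numbers for more inhibition at the one concentration tested (going by the name of the read-out):
compound 1 `C=CCc1cc(C(C)=O)c(O)cc1OCCCCCCCCC#N`, 86%
compound 2 `C=CCc1cc(C(C)=O)c(O)cc1OCCCC`, 32%
compound 3 `C=CCc1cc(C(C)=O)c(O)cc1OCCCCC`, 60%

Compound 3 stands second of the three in this assay: compound 1 sits a number 26 percentage points lower from compound 1 to compound 3 (beyond the scatter), and compound 2 sits a number 28 percentage points higher from compound 2 to compound 3 (beyond the scatter).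

Compound 4 `C=CCc1cc(C(C)=O)c(O)cc1OCCCCCCC` is not yet measured. Against compound 3 the change is ethyl in place of hydrogen on a saturated chain carbon, five bonds along the chain from an oxygen on an aromatic ring.

For the measured compounds named here, two steps bear on this. Lengthening the chain by one carbon, methyl in place of hydrogen, gave a number 28 percentage points higher from compound 2 to compound 3 (beyond the scatter). Cutting the longer chain back, hydrogen in place of 3-cyanopropyl, gave a number 26 percentage points lower from compound 1 to compound 3 (beyond the scatter), and the larger cut gave a number 54 percentage points lower from compound 1 to compound 2 (beyond the scatter). Within these three compounds every added length on the chain from the oxygen on the aromatic ring went with a higher number, and no compound goes against that. Compound 4 carries a chain of intermediate length, so a rise beyond the scatter is expected, though smaller than the gap to compound 1, which also carries a nitrile. The expected step is a number 14 percentage points higher from compound 3 to compound 4 (beyond the scatter). Compound 4 is therefore estimated at 74%, in the range 58% to 90%.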

Compound 4, a percentage reported as inhibition, at one concentration (the size of the read-out at that concentration, not a potency): 31%
Beside the measured number, compound 4's estimate is 43 percentage points above it; the whole stated range lies above it.
By their numbers in this assay, from the lowest: compounds 4 and 2 (each within the scatter of the next); then compound 3; then compound 1.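

In this assay, ethyl in place of hydrogen, five bonds along the chain from an oxygen on an aromatic ring, gives a number 29 percentage points lower from compound 3 to compound 4 (beyond the scatter); the rise with added chain length seen so far therefore does not continue, and compound 4 goes against it. The step of a number 1 percentage points lower from compound 2 to compound 4 (within the scatter) shows no separation of these two chains, so among the chains without a nitrile only compound 3 stands apart. Hydrogen in place of cyanomethyl, seven bonds along the chain, gives a number 55 percentage points lower from compound 1 to compound 4 (beyond the scatter), so in this pair the high number goes with the nitrile-bearing chain end.

Nothing at hand gives a reason for the fall at this position. Open, on these data alone, are how a hexyl or octyl chain would read, and whether a carboxylic acid or an amine at the chain end would match the nitrile.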